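Swapping One Dialkylamino Group for Another on the Urea Scaffold

The compounds below may be only part of what the source reports. "The series", "measured", "known", "first", "only" and "open" are said of these compounds alone.

Compound 1, `Cc1ccc(NC(=O)Nc2cc(-c3ccc(C(=O)O)cc3)ccc2Oc2ccccc2C(C)(C)C)cc1`, was tested in an assay on HeLa cells for inhibition of Indoleamine 2,3-dioxygenase 1 (Homo sapiens), with stated times of 1 h and 18 h; on this read-out higher numbers stand for weaker inhibition and lower numbers for stronger inhibition. In this assay compound 1 gives only a limit of the assay, > 1000 nM, rather than a number. Compound 2, `CCN(c1ccc(-c2ccccc2C(=O)O)cc1NC(=O)Nc1ccc(C)cc1)C1CCCC1`, carries a cyclopentyl(ethyl)amino group and a 2-carboxyphenyl group. In this assay compound 2 gives 23 nM. Among the results so far this is the only actual number; the other entry is the limit of > 1000 nM in this assay, at which 1 of the 2 values shown sits, so compound 2 stands alone as the single measured point against which anything new can be compared.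

Compound 3, `Cc1ccc(NC(=O)Nc2cc(-c3ccccc3C(=O)O)ccc2N(CC(C)C)CC(C)C)cc1`, has not yet been measured. It differs from compound 2 in one place: diisobutylamino in place of cyclopentyl(ethyl)amino on an aromatic carbon. Among the compounds with values here, no measured pair of compounds shows what such an exchange of one dialkylamino group for another does here, so there is no measured step to lean on. The step of a 1.7-fold higher number from compound 2 to compound 3 (0.24 log units; within the scatter) is therefore expected to be modest, in either direction or none beyond the usual scatter. For compound 3 the expected value in this assay is 40 nM, with a range from 10 nM to 200 nM.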

Compound 3, half-maximal inhibitory concentration: 13 nM
Estimate against measurement, compound 3: 3.1-fold (0.49 log units) above; the measured number falls inside the stated range.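

In this assay, within the data shown here, putting diisobutylamino in place of cyclopentyl(ethyl)amino gives a 1.8-fold lower number from compound 2 to compound 3 (0.25 log units; within the scatter), the first measured step at this position, on the aromatic carbon ortho to the ((4-methylphenyl)carbamoyl)amino group and para to the 2-carboxyphenyl group. The two compounds therefore show that one dialkylamino group with a five-membered ring of carbon only and another with no ring can be exchanged here without the values leaving the usual scatter of each other, although this is one exchange and not a rule for all such groups. No measurement shown gives a reason for this outcome.

Among these compounds, whether a much smaller group such as dimethylamino, a plain amine or a morpholine ring at this position would stay within the same scatter remains open, since only two dialkylamino groups can be compared here. Compound 1 gives only a limit of the assay, > 1000 nM, and because it differs from compound 2 in more than one place, it cannot show what this position alone contributes.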